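The source may hold more compounds than are shown below. What is called first, only, known or untested is meant among the compounds shown, and "the series" means these compounds.

Compound 3 `O=c1cc(CC(COCc2ccccc2)COCc2ccccc2)[nH]c(=O)[nH]1` sits at the assay limit in a functional assay on HeLa cells (Homo sapiens) for antiproliferative activity, read by MTT assay, with a stated time of 72 h (a higher number here means a weaker inhibitor, a lower number a stronger inhibitor), where compound 3 gives > 100000 nM, a limit and not a number. Compound 2 `COc1cc(CC(COCc2ccccc2)COCc2ccccc2)nc(OC)n1` gives 3500 nM in this assay. The two are separated by an at least 28-fold higher number from compound 2 to compound 3 (1.45 log units; beyond the scatter). Compound 1 `COCn1c(CC(O)(COCc2ccccc2)COCc2ccccc2)cc(=O)[nH]c1=O` gives > 100000 nM in this assay, again a limit. Here the limit of > 100000 nM in this assay, at which 2 of the 3 values shown sit, marks the position of the series. Compound 4 `COCn1c(CC(COCc2ccccc2)COCc2ccccc2)cc(=O)[nH]c1=O` is the next member: methoxymethyl in place of hydrogen on an aromatic nitrogen. Going by the values given here, no measured step covers this change; compound 1, which differs from compound 4 only by an added hydroxyl, and compound 3 both return the limit. For compound 4 in this assay a further limit rather than a number is expected, with a number no higher from compound 3 to compound 4 (the limit leaves the size open) not beyond the scatter. Compound 4 is estimated at 100000 nM, range 30000 nM to 300000 nM.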

Compound 4, half-maximal inhibitory concentration: > 100000 nM
Compound 4 ended at the assay's limit (the forecaster's own chance of this, stated with the estimate: 80%); the middle value sits exactly at the limit.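

In this assay compound 1, compound 3 and compound 4 all give limits, so neither step to compound 4 can be read. The compounds shown leave open what methoxymethyl in place of hydrogen on the aromatic nitrogen, or hydrogen in place of hydroxy on the chain carbon, does to activity.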